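This account rests on a few compounds, and the source may have more. Where it says the series, first, only, none or still open, it means among the compounds named here.

Of the compounds shown here, two have numbers so far in an ADME assay on microsomes from liver (Rattus norvegicus) for metabolic stability, read by LC-MS, using NADPH, with a stated time of 30 min, tested at 1 uM (a higher number here means faster removal of the compound, a lower number slower removal), and they can be read side by side. Compound 1 (`CC#Cc1cncc(-c2ccc3c(c2)[C@@]2(COC(N)=N2)c2cc(-c4ccnc(F)c4)ncc2O3)c1`) stands at 20 mL.min-1.g-1 and compound 2 (`NC1=N[C@@]2(CO1)c1cc(-c3cncc(C#CC4CC4)c3)ccc1Oc1cnc(C3=CCOCC3)cc12`) at 23 mL.min-1.g-1 on the same read-out. These two numbers lie within the usual scatter of each other, so compound 2 cannot be told apart from compound 1 here.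

Compound 3 (`NC1=N[C@@]2(CO1)c1cc(-c3cncc(C#CCO)c3)ccc1Oc1cnc(C3=CCOCC3)cc12`) is compound 2 with a single change (hydroxymethyl in place of cyclopropyl on a triple-bonded carbon): hydroxymethyl in place of cyclopropyl on a triple-bonded carbon, which turns 2-cyclopropylethynyl into 3-hydroxyprop-1-yn-1-yl. Within the data shown here, no measured pair of compounds differs in this one place, so the data give no direct size for such a step. The expectation therefore starts from compound 2 at 23 mL.min-1.g-1 and is held loosely. Slower removal is expected, with a 1.9-fold lower number from compound 2 to compound 3 (0.28 log units; within the scatter) as the estimated step in this assay and with a real chance that it stays within the scatter. Compound 3 is estimated at 12 mL.min-1.g-1 within an expected range from 6 mL.min-1.g-1 to 22 mL.min-1.g-1 once it is measured.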

Compound 3, intrinsic clearance in microsomes: 46 mL.min-1.g-1
Estimate against measurement, compound 3: 3.8-fold (0.58 log units) below, and the stated range ends below it.
By their numbers in this assay, from the lowest: compounds 1, 2 and 3 (each within the scatter of the next, the first and the last beyond it).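

In this assay, among these compounds, the exchange of cyclopropyl for hydroxymethyl on a triple-bonded carbon gives a 2.0-fold higher number from compound 2 to compound 3 (0.30 log units; within the scatter) as the first step that can be read at this position. The change removes a three-membered ring of carbon only and brings in one hydrogen-bond donor and one hydrogen-bond acceptor, yet the two compounds cannot be told apart in this assay on this one pair, so this place carries either group without a resolved difference in the read-out. Nothing available here bears on why the two compounds read as they do.

The compounds shown leave open whether an aminomethyl group, a carboxylic acid or a longer chain ending in hydroxyl on the same triple-bonded carbon would give a step beyond the scatter. Among the compounds shown here, they also leave open whether the exchange of cyclopropyl for hydroxymethyl would give a step of similar size on a compound carrying a different group elsewhere on the shared core, since only one pair speaks to this change.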